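A few compounds are considered here, and "the series" means these few. Any claim that something is new, unique, unknown or untested is made for them only; others in the source may bear on it.

Compounds measured in an ADME assay on HEK293-A cells (Homo sapiens) for cytotoxicity, read by MTT assay, with a stated time of 48 h; a lower number here means a stronger inhibitor, a higher number a weaker inhibitor:
compound 1 `CCN1CCN(C[C@H]2CN(c3ccc(-n4cc(-c5ccccn5)cn4)c(F)c3)C(=O)O2)CC1` gives 99 ug/mL.
compound 2 `O=C1CNC(=O)N1C[C@H]1CN(c2ccc(-n3cc(-c4ccccn4)cn3)c(F)c2)C(=O)O1` gives a value that is only a limit of the assay, > 400 ug/mL.
compound 3 `O=C1O[C@@H](Cn2ccnc2)CN1c1ccc(-n2cc(-c3ccccn3)cn2)c(F)c1` also gives only a limit, > 400 ug/mL.

Compound 3 thus stands at the assay limit, with nothing more resolved; the limit of > 400 ug/mL in this assay, at which 2 of the 3 values shown sit, marks where it sits. Compound 4 `CCC(=O)NC[C@H]1CN(c2ccc(-n3cc(-c4ccccn4)cn3)c(F)c2)C(=O)O1` carries the change (propanoylamino in place of 1H-imidazol-1-yl on a saturated chain carbon bound to a saturated ring carbon). Within the data shown here, the steps that bear on it are an at least 4.0-fold higher number from compound 1 to compound 3 (0.60 log units; beyond the scatter) and an at least 4.0-fold higher number from compound 1 to compound 2 (0.60 log units; beyond the scatter), both running from a number to a limit, while a step that the two limits leave unreadable from compound 2 to compound 3 cannot be read. Both neutral replacements in this assay reached the limit, so for compound 4 the expected step is a number no higher from compound 3 to compound 4 (the limit leaves the size open), no direction resolvable. Compound 4 is therefore estimated at 400 ug/mL, within 200 ug/mL to 800 ug/mL.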

Compound 4, half-maximal inhibitory concentration: 389 ug/mL
Beside the measured number, compound 4's estimate is 1.0-fold (0.01 log units) above it; low and high end bracket the measured number.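

In this assay, a replacement with no ring also moves clear of the 4-ethylpiperazin-1-yl compound: a 3.9-fold higher number from compound 1 to compound 4 (0.59 log units; beyond the scatter). So the higher numbers at this saturated chain carbon do not depend on a five-membered ring in the entering group. Against compound 2 and compound 3, whose values are limits, only floors can be read, an at least 1.0-fold lower number from compound 2 to compound 4 (0.01 log units; that floor lies within the scatter) and an at least 1.0-fold lower number from compound 3 to compound 4 (0.01 log units; that floor lies within the scatter), so no order among the three is resolved: the limit of > 400 ug/mL in this assay, at which 2 of the 4 values shown sit.

Open, from the compounds shown here alone, is whether a simple amine or a carboxylic acid at this place would give a number nearer compound 1 or stay near the limit. A longer acyl chain than propanoylamino is equally unresolved.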